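The compounds below may be only part of what the source reports. "The series", "measured", "known", "first", "only" and "open" are said of these compounds alone.

Compound 1 `N[C@@H]1CCN(c2cc3c(cc2F)c(=O)c(C(=O)O)cn3Cc2ccc(-c3ccccc3)cc2)C1` in an assay on isolated protein for inhibition of DNA topoisomerase 1 (Homo sapiens), with a stated time of 15 min (on this read-out higher numbers stand for weaker inhibition and lower numbers for stronger inhibition), gives 63600 nM. Compound 2 `COc1c(N2CC[C@@H](C(N)=O)C2)c(F)cc2c(=O)c(C(=O)O)cn(Cc3ccc(-c4ccccc4)cc3)c12` in this assay gives only a limit, > 200000 nM.

Within the data shown here, compound 1 thus carries the only number among the two values shown. Compound 2 sits at the limit of > 200000 nM in this assay, at which 1 of the 2 values shown sits.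

Compound 3 `O=C(O)c1cn(Cc2ccc(-c3ccccc3)cc2)c2cc(N3C[C@H]4CCNC[C@H]4C3)c(F)cc2c1=O` differs from compound 1 by a group of 9 heavy atoms (7 carbon, 2 nitrogen; one five-membered non-aromatic ring with 1 hetero atom, one six-membered non-aromatic ring with 1 hetero atom) in place of a group of 6 heavy atoms (4 carbon, 2 nitrogen; one five-membered non-aromatic ring with 1 hetero atom), on an aromatic carbon, on an aromatic carbon of the shared core. Among the measured compounds shown here, no measured pair matches this change, so the expected step from compound 1 to compound 3 in this assay is a 1.3-fold lower number from compound 1 to compound 3 (0.10 log units; within the scatter), about none beyond the scatter. Compound 3 is estimated at 50000 nM, between 15000 nM and 200000 nM.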

Compound 3, half-maximal inhibitory concentration: 61000 nM
Compound 3: middle estimate off by 1.2-fold (0.09 log units), on the low side; low and high end bracket the measured number.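

Putting the group with a five-membered and a six-membered non-aromatic ring in place of the 3-aminopyrrolidin-1-yl group, on the aromatic carbon ortho to the fluoro group, gives in this assay a 1.0-fold lower number from compound 1 to compound 3 (0.02 log units; within the scatter). This position therefore takes the larger group, with its added six-membered ring, without a shift beyond the scatter. Nothing shown here accounts for this result.

Going by these compounds, whether a morpholine ring or an open-chain dimethylamino group at this position would shift the number remains open. So does the effect of replacing the carboxylic acid on the shared core.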